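Moving the chlorine around the phenyl on the triazole nitrogen

The source may report more compounds than this note shows. Statements on the series, on what has been measured and on what is new or still open speak of the compounds shown alone.

Measured so far:
compound 1 `CCc1ccccc1-n1nncc1CN1C(=O)C2(C(C#N)=C(N)Oc3c(N)cc4nc5ccccc5nc4c32)c2ccccc21`, 10300 nM
compound 2 `N#CC1=C(N)Oc2c(N)cc3nc4ccccc4nc3c2C12C(=O)N(Cc1cnnn1-c1cc(Cl)ccc1Cl)c1ccccc12`, > 50000 nM

Of the compounds shown here, two of this shared core have been measured in a functional assay on HCT-116 cells (Homo sapiens) for antiproliferative activity, read by MTT assay, with a stated time of 48 h; on this read-out lower numbers stand for stronger inhibition and higher numbers for weaker inhibition. Compound 1 carries 2-ethylphenyl on the aromatic nitrogen and gives 10300 nM. For compound 2, which carries 2,5-dichlorophenyl at that place, the assay reports only a limit, > 50000 nM, so its true value is not known as a number; this limit is the one of the limit of > 50000 nM in this assay, at which 1 of the 2 values shown sits. Within the data shown here, the only measured step, an at least 4.8-fold higher number from compound 1 to compound 2 (0.68 log units; beyond the scatter), thus ran toward weaker inhibition when the aryl group on the aromatic nitrogen was exchanged.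

Compound 3 `Cc1ccc(-n2nncc2CN2C(=O)C3(C(C#N)=C(N)Oc4c(N)cc5nc6ccccc6nc5c43)c3ccccc32)cc1Cl` differs from compound 2 by 3-chloro-4-methylphenyl in place of 2,5-dichlorophenyl on an aromatic nitrogen. Among the measured compounds shown here, no measured step joins a 3-chloro-4-methylphenyl group to either of the measured aryl groups, so the step from compound 1 to compound 2 is the only guide, and it shows that this position can move the number well beyond the scatter. Because compound 2 sits at a limit, the step of an at least 1.6-fold lower number from compound 2 to compound 3 (0.22 log units; that floor lies within the scatter) expected here cannot be sized from a known starting number. Compound 3 is estimated at 30000 nM in this assay, within a range from 8000 nM to 50000 nM.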

Compound 3, half-maximal inhibitory concentration: > 50000 nM
Compound 3 was reported as a limit (the forecaster's own chance of this, stated with the estimate: 45%); middle value at least 1.6-fold (0.22 log units) away from the limit.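

In this assay compound 3 is reported only as a limit, > 50000 nM. Putting 3-chloro-4-methylphenyl in place of 2-ethylphenyl on the aromatic nitrogen gives an at least 4.8-fold higher number from compound 1 to compound 3 (0.68 log units; beyond the scatter), so the move toward weaker inhibition is no longer tied to the 2,5-dichlorophenyl group alone: two differently substituted chlorophenyl groups now go the same way. The step between compound 2 and compound 3 cannot be read, and their two aryl groups cannot be ranked against each other, because both compounds stand at the same limit: the limit of > 50000 nM in this assay, at which 2 of the 3 values shown sit.

Of the three aryl groups, only the 2-ethylphenyl group carries no chlorine and only compound 1 gives a number, yet these compounds cannot tell whether that reading goes with the ethyl group, with the absence of chlorine, or with the way the phenyl is substituted. Going by these compounds, it also remains open whether a plain phenyl, a methoxyphenyl or an aminophenyl on the same nitrogen would give a number equal to or lower than that of compound 1, or would also end at a limit.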